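Pyrrolyl for Cyano: Cytotoxicity Expected to Stay Low

A few compounds are considered here, and "the series" means these few. Any claim that something is new, unique, unknown or untested is made for them only; others in the source may bear on it.

Compound 1 `N#Cc1ccc(NCc2cncn2Cc2ccc(-c3ccccc3)cc2)cc1-c1ccccc1` was examined in a toxicity assay on NIH3T3 cells (Mus musculus) for cytotoxicity, read by resazurin assay; on this read-out higher numbers stand for an effect only at larger amounts of compound and lower numbers for an effect already at smaller amounts. In this assay compound 1 gives > 1000 nM, which is a limit of the assay rather than a number. Compound 2 `N#Cc1ccc(NCc2cncn2Cc2ccc(-c3ccccc3)cc2N)cc1-c1ccccc1` carries amino in place of hydrogen on an aromatic carbon; in this assay compound 2 gives > 1000 nM, again a limit. The step that the two limits leave unreadable from compound 1 to compound 2 therefore cannot be read. Compound 3 `c1ccc(Cn2cncc2CNc2cccc(-c3ccccc3)c2)cc1` was measured as well; in this assay compound 3 gives > 750 nM, also a limit. Compound 1 thus stands at the limit of > 1000 nM in this assay, at which 2 of the 3 values shown sit, together with compound 2, while compound 3 sits at the limit of > 750 nM in this assay, at which 1 of the 3 values shown sits. Compound 4 `c1ccc(-c2ccc(Cn3cncc3CNc3ccc(-c4ccc[nH]4)c(-c4ccccc4)c3)cc2)cc1` differs from compound 1 in one place: 1H-pyrrol-2-yl in place of cyano on an aromatic carbon. Among the measured compounds shown here, no measured step bears directly on this change, and every value shown sits at a limit, so no readable step in either direction is expected, only a result at or beyond the limit. Compound 4 is estimated at 2500 nM, expected between 800 nM and 10000 nM. This estimate implies an expected step that the limit leaves unreadable from compound 1 to compound 4, which would itself stay unreadable against the limit.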

Compound 4, half-maximal effective concentration: > 10000 nM
Compound 4 was reported as a limit; the forecaster's own chance of this, stated with the estimate: 70%; middle value at least 4.0-fold (0.60 log units) from the limit.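

In this assay compound 4 gives > 10000 nM, a limit and not a number. Compound 1 also stands at a limit, so the step between compound 1 and compound 4 cannot be read. The compounds shown leave open at what concentration any of them would show an effect, and whether 1H-pyrrol-2-yl in place of cyano shifts it.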